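Two Quinazolin-4-yl Ethers and a Third to Measure

The compounds below may be only part of what the source reports. "The series", "measured", "known", "first", "only" and "open" are said of these compounds alone.

Compound 2 `Cc1cccc2ncnc(O/N=C(\C=C\c3ccccn3)/C=C/c3ccccc3OCc3ccccc3Cl)c12` gives 86.8% in a functional assay on SMMC-7721 cells (Homo sapiens) for inhibition, read by MTT assay, with a stated time of 72 h, tested at 1 uM; on this read-out higher numbers stand for a stronger effect at the one concentration tested and lower numbers for a weaker effect. Compound 1 `Fc1ccccc1COc1ccccc1/C=C/C(/C=C/c1ccccn1)=N/Oc1ncnc2cc(Cl)ccc12` gives 94.2% in this assay, and these two values lie within the scatter of each other, so neither compound stands apart. Compound 3 `Clc1ccc2c(O/N=C(\C=C\c3ccccn3)/C=C/c3ccccc3OCc3ccccc3Cl)ncnc2c1` carries 7-chloroquinazolin-4-yl in place of 5-methylquinazolin-4-yl on an oxygen. Compound 1, which already bears the 7-chloroquinazolin-4-yl group, gives 94.2% in this assay. On that basis the step of a number 3.2 percentage points higher from compound 2 to compound 3 (within the scatter) is expected to be small, in neither direction beyond the scatter. Compound 3 is therefore expected to give about 90%, within a range from 78% to 97%.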

Compound 3, a percentage reported as inhibition, at one concentration (the size of the read-out at that concentration, not a potency): 94.8%
For compound 3 the middle estimate is 4.8 percentage points below the measured one; the measured number falls inside the stated range.
By their numbers in this assay, from the lowest: compounds 2, 1 and 3 (each within the scatter of the next).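

In this assay the exchange of 5-methylquinazolin-4-yl for 7-chloroquinazolin-4-yl on an oxygen can now be read directly, as a number 8 percentage points higher from compound 2 to compound 3 (within the scatter), so at this place the two groups are not told apart. Chloro in place of fluoro on an aromatic carbon gives a number 0.6 percentage points higher from compound 1 to compound 3 (within the scatter), and this read-out does not tell those two apart either. Nothing available bears on these results. The compounds shown leave open whether an amine or a carboxylic acid in place of chloro on that aromatic carbon would give a step beyond the scatter. All three compounds were tested at a single concentration, so these numbers describe the size of the effect at that concentration only.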